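The compounds below may be only part of what the source reports. "The series", "measured", "known", "first", "only" and "open" are said of these compounds alone.

Measured compounds:
- compound 1 `COc1ccccc1/C=c1\c(=O)[nH]/c(=C/c2cccc(Cl)c2Cl)c(=O)n1C`: 200 nM
- compound 2 `COc1ccccc1/C=c1\c(=O)[nH]/c(=C/c2ccccc2Cl)c(=O)n1C`: 200 nM
- compound 3 `C=CCn1c(=O)/c(=C\c2ccc(F)c(Br)c2)[nH]c(=O)/c1=C\c1ccccc1OC`: "not active" (no number reported)

In a functional assay on MCF7 cells (Homo sapiens) for cytotoxicity, read by CCK-8 assay, with a stated time of 72 h (on this read-out lower numbers stand for stronger inhibition and higher numbers for weaker inhibition), compound 1 gives 200 nM and compound 2 gives 200 nM; the step of no change at the digits printed from compound 1 to compound 2 (within the scatter) is within the scatter. Compound 3 stands apart: in this assay compound 3 gives "not active" (no number reported), so no number is available for it, and it shares its core with compound 4 `C=CCn1c(=O)/c(=C\c2cccc(Cl)c2)[nH]c(=O)/c1=C\c1ccccc1OC` rather than with compound 1 or compound 2. The change from compound 3 to compound 4 is 3-chlorophenyl in place of 3-bromo-4-fluorophenyl on a double-bonded chain carbon bound to an aromatic carbon.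

Among the compounds with values here, no measured step covers this change directly. Within the data shown here, the only step recorded, no change at the digits printed from compound 1 to compound 2 (within the scatter), concerns a halogen on the aromatic ring in a different core and showed no change beyond the scatter, which offers little guidance here, and the absence of a number for compound 3 leaves the size and direction of the step open. Compound 4 is therefore expected to be weak, estimated at 3000 nM in this assay, with a wide range from 300 nM to 30000 nM, and a real chance that the assay again reports no number.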

Compound 4, half-maximal inhibitory concentration: 5200 nM
For compound 4 the middle estimate is 1.7-fold (0.24 log units) below the measured one; the range from low to high includes it.
By their numbers in this assay, from the lowest: compounds 1 and 2 (each within the scatter of the next); then compound 4.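

No new step can be read, since compound 3 has no number in this assay and its change to compound 4 therefore has no size. What replacing 3-bromo-4-fluorophenyl with 3-chlorophenyl does stays open, and no measurement shown here offers an explanation for the value of compound 4.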